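Compound 3 to compound 4: cytotoxicity at the limit

This account rests on a few compounds, and the source may have more. Where it says the series, first, only, none or still open, it means among the compounds named here.

In a functional assay on Huh-7 cells (Homo sapiens) for cytotoxicity, read by MTT assay, with a stated time of 3 days (a higher number here means that more compound is tolerated, a lower number that less compound is tolerated), compound 3 (`OC[C@H]1O[C@@H](n2cnc3c(COc4ccccn4)ncnc32)[C@H](O)[C@@H]1O`) gives > 250000 nM, a limit and not a number. Compound 1 (`OC[C@H]1O[C@@H](n2cnc3c(CSc4ccccn4)ncnc32)[C@H](O)[C@@H]1O`) gives > 100000 nM, also a limit. Compound 2 (`OC[C@H]1O[C@@H](n2cnc3c(CSCc4ccccc4)ncnc32)[C@H](O)[C@@H]1O`) gives > 100000 nM, again a limit.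

Compound 4 (`O=C1CCCN1Cc1ncnc2c1ncn2[C@@H]1O[C@H](CO)[C@@H](O)[C@H]1O`) carries 2-oxopyrrolidin-1-yl in place of (pyridin-2-yl)oxy on a saturated chain carbon bound to an aromatic carbon.

The measured steps, a step that the two limits leave unreadable from compound 1 to compound 2, a step that the two limits leave unreadable from compound 1 to compound 3 and a step that the two limits leave unreadable from compound 2 to compound 3, have no readable size, and on them no shift beyond the usual scatter is expected in this assay. The expected step is a number no higher from compound 3 to compound 4 (the limit leaves the size open). The estimate for compound 4 is 250000 nM, with an expected range from 100000 nM to 500000 nM.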

Compound 4, half-maximal cytotoxic concentration: 45000 nM
For compound 4 the middle estimate is 5.6-fold (0.74 log units) above the measured one; measured number outside the range, below it.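

In this assay compound 4 is the only compound here that gives a number and not a limit, so 2-oxopyrrolidin-1-yl at this saturated chain carbon is the first group shown with a measurable cytotoxic concentration. It gives an at least 5.5-fold lower number from compound 3 to compound 4 (0.74 log units; beyond the scatter), as well as an at least 2.2-fold lower number from compound 2 to compound 4 (0.34 log units; beyond the scatter) and an at least 2.2-fold lower number from compound 1 to compound 4 (0.34 log units; beyond the scatter), each a minimum size, while the steps among compound 1, compound 2 and compound 3 cannot be read. The two smaller minimums rest on one shared limit: the limit of > 100000 nM in this assay, at which 2 of the 4 values shown sit.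

The compounds shown leave open whether the carbonyl or the ring of 2-oxopyrrolidin-1-yl goes with the step. A plain pyrrolidin-1-yl amine on the same carbon would separate the two.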